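The compounds below may be only part of what the source reports. "The series", "measured", "known", "first", "only" and "open" are said of these compounds alone.

Among the measured compounds shown here, in a functional assay on A549 cells (Homo sapiens) for cytotoxicity, read by sulforhodamine B assay, with a stated time of 48 h (a higher number here means a weaker inhibitor, a lower number a stronger inhibitor), two compounds have numbers so far. Compound 1 `CCn1cc(-c2nc3ccccc3[nH]2)c(=O)c2cc(F)c(N3CCNCC3)nc21` gives 7800 nM, and compound 2 `CCn1cc(-c2nc3ccc([N+](=O)[O-])cc3[nH]2)c(=O)c2cc(F)c(N3CCNC(C)C3)c(F)c21` gives 2400 nM. Compound 1 therefore stands at the higher of the two numbers, making it the weaker inhibitor of this pair, and the gap lies beyond the usual scatter of repeated measurements.

Compound 3 `CCn1cc(-c2nc3ccc(N)cc3[nH]2)c(=O)c2cc(F)c(N3CCNCC3)nc21` keeps the core of compound 1 and changes it in one place, with amino in place of hydrogen on an aromatic carbon. For the measured compounds named here, no measured pair shows a change of this kind, so the data give no direct guide to its size. In this assay, a modest move towards a lower number is expected, one that may stay within the scatter. The expected step is a 1.4-fold lower number from compound 1 to compound 3 (0.15 log units; within the scatter). Compound 3 is estimated at 5500 nM, with an expected range from 1800 nM to 17000 nM.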

Compound 3, half-maximal inhibitory concentration: > 10000 nM
Compound 3 ended at the assay's limit; the forecaster's own chance of this, stated with the estimate: 10%; at least 1.8-fold (0.25 log units) between middle value and limit.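

In this assay, compound 3 gives > 10000 nM, which is a limit of the assay and not a number. Amino in place of hydrogen on this aromatic carbon gives an at least 1.2-fold higher number from compound 1 to compound 3 (0.10 log units; that floor lies within the scatter), so this single change shows no gain in cytotoxicity on the core of compound 1, the first direct reading of any change at this place. Only a floor for the step can be read, and its true size remains unknown: the limit of > 10000 nM in this assay, at which 1 of the 3 values shown sits.

The compounds shown leave open how other groups on this same carbon would behave, for example a methoxy group, a carboxylic acid or an acetylamino group. They also leave open whether amino in place of hydrogen would give a similar result on a different core.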